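The compounds below may be only part of what the source reports. "The series", "measured", "known", "first", "only" and "open" are said of these compounds alone.

Of the compounds shown here, three that share one core have been measured in a functional assay on HepG2 cells (Homo sapiens) for inhibition, read by MTT assay, with a stated time of 48 h; a lower number here means a stronger inhibitor, a higher number a weaker inhibitor. Compound 1 `CCc1ccc(-c2nc3ccccn3c2Sc2ccccc2)cc1` gives 50200 nM, compound 2 `Cc1ccc(-c2nc3ccccn3c2Sc2ccccc2)cc1` gives 67900 nM, and compound 3 `CSc1ccc(-c2nc3ccccn3c2Sc2ccccc2)cc1` gives 7600 nM. Compound 3 therefore holds the lowest number of the three, clear of both others. Compound 4 `N#Cc1ccc(-c2nc3ccccn3c2Sc2ccccc2)cc1`, still unmeasured, differs from compound 3 in one place: cyano in place of methylsulfanyl on an aromatic carbon, para to a large group (cyano in place of methylsulfanyl on an aromatic carbon).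

Among the compounds with values here, no measured compound carries cyano, so no step speaks to that group directly. The nearest evidence comes from exchanges on the same aromatic carbon. Methylsulfanyl in place of ethyl gives a 6.6-fold lower number from compound 1 to compound 3 (0.82 log units; beyond the scatter), and methylsulfanyl in place of methyl gives an 8.9-fold lower number from compound 2 to compound 3 (0.95 log units; beyond the scatter), both modest. Hydrogen in place of methyl on the chain gives only a 1.4-fold higher number from compound 1 to compound 2 (0.13 log units; within the scatter), within the scatter. As far as these compounds go, on the evidence of an 8.9-fold lower number from compound 2 to compound 3 (0.95 log units; beyond the scatter), losing methylsulfanyl is expected to give back part of that difference, though probably not all of it, since cyano is untested. The expected change in this assay is a 3.3-fold higher number from compound 3 to compound 4 (0.52 log units; beyond the scatter). For compound 4 the estimated value is 25000 nM, with an expected range from 7000 nM to 80000 nM.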

Compound 4, half-maximal inhibitory concentration: 15700 nM
Estimate against measurement, compound 4: 1.6-fold (0.20 log units) above; low and high end bracket the measured number.
By their numbers in this assay, from the lowest: compound 3; then compound 4; then compounds 1 and 2 (each within the scatter of the next).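

In this assay, the position on the aromatic carbon para to a large group now carries a fourth group, and cyano in place of methylsulfanyl gives a 2.1-fold higher number from compound 3 to compound 4 (0.32 log units; beyond the scatter), so methylsulfanyl keeps the lowest number, though this step is smaller than those separating methylsulfanyl from the two alkyl groups. Cyano in place of methyl gives a 4.3-fold lower number from compound 2 to compound 4 (0.64 log units; beyond the scatter), and cyano in place of ethyl gives a 3.2-fold lower number from compound 1 to compound 4 (0.50 log units; beyond the scatter), which shows that a number clearly lower than those of the methyl and ethyl compounds is not confined to methylsulfanyl at this position. Nothing available measures any property that would explain this order, so the steps describe the order without accounting for it.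

The compounds shown leave open whether methoxy, an amine, a carboxylic acid, chlorine or the longer ethylsulfanyl at the same position would fall nearer to methylsulfanyl or to the alkyl groups. They also leave open whether the same order would hold with a change elsewhere on the shared core, which stays the same in all four compounds.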